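Moving one bromine: from compound 3 to compound 4

The source may report more compounds than this note shows. Statements on the series, on what has been measured and on what is new or still open speak of the compounds shown alone.

In a functional assay on MDA-MB-231 cells (Homo sapiens) for cytotoxicity, read by MTT assay, with a stated time of 68 h (a higher number here means a weaker inhibitor, a lower number a stronger inhibitor), three compounds on one shared core have been measured. Compound 1 `O=C(/C=C/c1cccc(OCc2ccccc2)c1)c1ccc([N+](=O)[O-])cc1` gives 23300 nM and compound 2 `O=C(/C=C/c1cccc(OCc2ccccc2)c1)c1ccc(Cl)cc1Cl` gives 6800 nM while compound 3 `O=C(/C=C/c1cccc(OCc2ccccc2)c1)c1ccccc1Br` gives 1800 nM as the lowest number of the three. Next comes compound 4 `O=C(/C=C/c1cccc(OCc2ccccc2)c1)c1cccc(Br)c1` with the same atoms joined differently. The change is 3-bromophenyl in place of 2-bromophenyl on a carbonyl carbon and amounts to 3-bromophenyl in place of 2-bromophenyl on a carbonyl carbon. Within the data shown here, no measured step moves a bromine, so nothing answers this directly. Two steps change the group on that same carbonyl carbon and set a rough scale. Among the measured compounds shown here, the modest one is a 3.8-fold lower number from compound 2 to compound 3 (0.58 log units; beyond the scatter) and the large one is a 13-fold lower number from compound 1 to compound 3 (1.11 log units; beyond the scatter) and both end at the lowest number so far. With compound 3 at 1800 nM as the lowest value yet, a rise is more likely than a further fall. The expected change is a 2.2-fold higher number from compound 3 to compound 4 (0.35 log units; beyond the scatter) as a modest step upward. For compound 4 the estimated value is 4000 nM with an expected range from 1500 nM to 12000 nM as the likely span.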

Compound 4, half-maximal inhibitory concentration: 6900 nM
For compound 4 the middle estimate is 1.7-fold (0.24 log units) below the measured one; measured number inside the range.
By their numbers in this assay, from the lowest: compound 3; then compounds 2 and 4 (each within the scatter of the next); then compound 1.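

In this assay the place of the bromine matters by itself: with the same atoms, 3-bromophenyl in place of 2-bromophenyl gives a 3.8-fold higher number from compound 3 to compound 4 (0.58 log units; beyond the scatter) on the shared core. That single change removes the lead that compound 3 held over compound 2, since a 1.0-fold higher number from compound 2 to compound 4 (0.01 log units; within the scatter) leaves these two compounds within the scatter of each other. The 3-bromophenyl group still keeps a gap to the 4-nitrophenyl group, as a 3.4-fold lower number from compound 1 to compound 4 (0.53 log units; beyond the scatter) shows for the same carbonyl carbon.

Going by these compounds, whether a methoxy group or an amine on this ring would also depend on its place remains open. Nothing given here explains why the place of the bromine changes the number.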